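Compound 2 and a swapped group on the amine nitrogen

The source may hold more compounds than are shown below. What is called first, only, known or untested is meant among the compounds shown, and "the series" means these compounds.

- Compound 1 `COc1c([C@H](C)n2nc(C)c3c(N)ncnc32)cc(Cl)c(C)c1C1CNC(=O)C1` gives 2.8 10^-6 cm/s
- Compound 2 `COc1c([C@H](C)Nc2ncnc3[nH]cnc23)cc(Cl)c(C)c1-c1cncc(S(C)(=O)=O)c1` gives 0.5 10^-6 cm/s

In an ADME assay on Caco-2 cells (Homo sapiens) for permeability, read by LC-MS, in the apical to basolateral direction, with a stated time of 120 min, tested at 50 uM (on this read-out lower numbers stand for lower permeability and higher numbers for higher permeability), compound 2 gives 0.5 10^-6 cm/s and compound 1 gives 2.8 10^-6 cm/s. The number of compound 2 is the lower of the two, and the gap between them lies beyond the scatter. Compound 3 `COc1c([C@H](C)Nc2ncnc(N)c2C#N)cc(Cl)c(C)c1-c1cncc(S(C)(=O)=O)c1` keeps the rest of compound 2 and changes one group on an amine nitrogen (a group of 9 heavy atoms (5 carbon, 4 nitrogen; one six-membered aromatic ring with 2 hetero atoms) in place of a group of 9 heavy atoms (5 carbon, 4 nitrogen; one five-membered aromatic ring with 2 hetero atoms, one six-membered aromatic ring with 2 hetero atoms), on an amine nitrogen). Among the compounds with values here, no measured pair shows this change on its own, so the expectation is tentative. The expected step is a 1.8-fold higher number from compound 2 to compound 3 (0.26 log units; within the scatter) and thus a small upward one, within the scatter. Compound 3 is estimated at 0.9 10^-6 cm/s (expected range 0.3 10^-6 cm/s to 3 10^-6 cm/s).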

Compound 3, apparent permeability: 7.9 10^-6 cm/s
Beside the measured number, compound 3's estimate is 8.8-fold (0.94 log units) below it; measured number above the stated range.
By their numbers in this assay, from the lowest: compound 2; then compound 1; then compound 3.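

In this assay, putting 6-amino-5-cyanopyrimidin-4-yl on the amine nitrogen gives a 16-fold higher number from compound 2 to compound 3 (1.20 log units; beyond the scatter) and shows that this place can move the read-out well beyond the scatter, even when the leaving and entering groups hold the same atoms. The entering group has one ring instead of two, a triple bond and one more hydrogen-bond acceptor, with the donor count unchanged. Nothing available accounts for the step. The compounds shown leave open whether the amino group or the nitrile carries this step, and whether a methylamino group in place of that amino group would keep it.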